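From a Dimethylamino Chain to a Diethyl Amide

The source may hold more compounds than are shown below. What is called first, only, known or untested is meant among the compounds shown, and "the series" means these compounds.

In a physicochemical assay for solubility, in phosphate buffer, with a stated time of 18 h, at pH 7.4 (a lower number here means a less soluble compound, a higher number a more soluble compound), compound 3 `COc1cc2ncnc(-n3nc(-c4ccccn4)nc3N)c2cc1OCCCN(C)C` gives 53000 nM and stands level, within the scatter, with compound 2 `COc1cc2ncnc(-n3nc(N)nc3N)c2cc1OC` at 83000 nM while compound 1 `COc1cc2ncnc(-n3nc(-c4ccccn4)nc3N)c2cc1N` lies far lower at 3000 nM in the same test. Compound 4 `CCN(CC)C(=O)COc1cc2c(-n3nc(-c4ccccn4)nc3N)ncnc2cc1OC` differs from compound 3 by diethylcarbamoyl in place of 2-(dimethylamino)ethyl on a saturated chain carbon bound to an oxygen on an aromatic ring with diethylcarbamoyl in place of 2-(dimethylamino)ethyl on a saturated chain carbon bound to an oxygen on an aromatic ring. Within the data shown here, the only measured step bearing on this is an 18-fold higher number from compound 1 to compound 3 (1.25 log units; beyond the scatter) on exchanging amino for 3-(dimethylamino)propoxy, and compound 4 no longer has that chain, so a fall beyond the scatter is expected in this assay here. The estimated change is a 5.9-fold lower number from compound 3 to compound 4 (0.77 log units; beyond the scatter) in size. Compound 4 is estimated at 9000 nM with a range from 2500 nM to 30000 nM in this test.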

Compound 4, solubility: 42000 nM
Beside the measured number, compound 4's estimate is 4.7-fold (0.67 log units) below it; the whole stated range lies below it.
By their numbers in this assay, from the lowest: compound 1; then compounds 4, 3 and 2 (each within the scatter of the next).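

In this assay the exchange of 2-(dimethylamino)ethyl for diethylcarbamoyl on a saturated chain carbon bound to an oxygen on an aromatic ring gives a 1.3-fold lower number from compound 3 to compound 4 (0.10 log units; within the scatter) so the high number at this place does not rest on the dimethylamino group. The amide chain keeps the distance from the amino compound as well, with a 14-fold higher number from compound 1 to compound 4 (1.15 log units; beyond the scatter) on (diethylcarbamoyl)methoxy in place of amino. No evidence here explains this result. On these data alone, whether a carboxylic acid or a morpholine in place of diethylcarbamoyl would hold the number at this level remains open.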